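The source may hold more compounds than are shown below. What is called first, only, known or untested is meant among the compounds shown, and "the series" means these compounds.

Measured compounds:
- compound 1 `CN(C)C(=O)c1cccnc1NCCCN1CCN(c2ccccc2OC(F)(F)F)CC1`, 3.16 nM
- compound 2 `CN(C)C(=O)c1cccnc1NCCCN1CCN(c2ccccc2-c2ncco2)CC1`, 0.316 nM
- compound 3 `Cc1cnccc1N1CCN(CCCNc2ncccc2C(=O)N(C)C)CC1`, 200 nM

These three share one core and differ only in the aromatic group carried on the amine nitrogen in the ring. In a functional assay for antagonist activity at Alpha-1A adrenergic receptor (Oryctolagus cuniculus) (a higher number here means weaker binding, a lower number tighter binding), compound 3 gives the highest of the three numbers, so it is the weakest binder here: compound 1 gives 3.16 nM and compound 2 gives 0.316 nM, both far lower. For the measured compounds named here, the one measured step, a 10-fold lower number from compound 1 to compound 2 (1.00 log units; beyond the scatter), concerns a swap of substituents on an aromatic carbon and does not touch the change at hand; it does show how much a change on that ring can move the number.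

Compound 4 `CSc1ccccc1N1CCN(CCCNc2ncccc2C(=O)N(C)C)CC1` carries the change (2-(methylsulfanyl)phenyl in place of 3-methylpyridin-4-yl on an amine nitrogen in a ring). Compound 4 thus gains a substituted phenyl ring of the same kind borne by compounds 1 and 2, while compound 3 bears a pyridine instead. The values of compounds 1 and 2 show that this ring type goes with much lower numbers than compound 3 has. A large fall is therefore expected in this assay, a 40-fold lower number from compound 3 to compound 4 (1.60 log units; beyond the scatter), toward the region of compound 1 because of 3.16 nM. Compound 4 is estimated at 5 nM, within 1 nM to 30 nM.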

Compound 4, dissociation constant: 0.631 nM
Estimate against measurement, compound 4: 7.9-fold (0.90 log units) above; the whole stated range lies above it.
By their numbers in this assay, from the lowest: compounds 2 and 4 (each within the scatter of the next); then compound 1; then compound 3.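

Putting 2-(methylsulfanyl)phenyl in place of 3-methylpyridin-4-yl on an amine nitrogen in a ring gives a 320-fold lower number from compound 3 to compound 4 (2.50 log units; beyond the scatter) in this assay, so the choice of this aromatic group can decide between a weak and a tight binder. On the phenyl ring, methylsulfanyl in place of trifluoromethoxy gives a 5.0-fold lower number from compound 1 to compound 4 (0.70 log units; beyond the scatter), while methylsulfanyl in place of 1,3-oxazol-2-yl gives a 2.0-fold higher number from compound 2 to compound 4 (0.30 log units; within the scatter), so a second ring at that aromatic carbon is not needed to reach a number in this low region. Nothing shown here explains why these changes move the number as they do.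

As far as these compounds go, compound 3 and compound 4 differ in both the ring and its substituent, so the share of each in the step stays unknown. An unsubstituted phenyl ring, or a 2-methoxyphenyl group, would help separate them.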